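The source may hold more compounds than are shown below. What is called first, only, known or untested is meant among the compounds shown, and "the series" means these compounds.

Values so far in a functional assay on MDA-MB-231 cells (Homo sapiens) for cytotoxicity, read by MTT assay, with a stated time of 48 h; on this read-out lower numbers stand for stronger inhibition and higher numbers for weaker inhibition
Compound 1 `COc1cc(C2=NOC(c3cc(OC)c(OC)c(OC)c3)C2)ccc1O`: 3600 nM
Compound 2 `COc1ccc(C2=NOC(COc3ccc(-c4nnnn4-c4cc(OC)c(OC)c(OC)c4)cc3N)C2)cc1OC`: 3570 nM
Compound 3 `COc1cc(C2=NOC(COc3ccc(-c4nnnn4-c4cc(OC)c(OC)c(OC)c4)cc3N)C2)cc(OC)c1OC`: 3230 nM

All three values lie within the usual scatter of one another, so compound 2 stands level with compound 1 and compound 3. Compound 4 `COc1ccc(C2=NOC(COc3ccc(-c4nnnn4-c4cc(OC)c(OC)c(OC)c4)cc3N)C2)cc1O` differs from compound 2 by hydrogen in place of methyl on an oxygen on an aromatic ring, which gives 3-hydroxy-4-methoxyphenyl from 3,4-dimethoxyphenyl. Within the data shown here, the one measured step, a 1.1-fold lower number from compound 2 to compound 3 (0.04 log units; within the scatter), is a different change, methoxy in place of hydrogen on an aromatic carbon, and it bears only indirectly. Compound 1, which also carries a hydroxy on an aromatic ring, gives 3600 nM and is level with compound 2. No shift beyond the scatter is therefore expected in this assay, and the estimated 1.2-fold lower number from compound 2 to compound 4 (0.08 log units; within the scatter) is small. For compound 4 the expected value is 3000 nM, with an estimated range from 1300 nM to 7000 nM.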

Compound 4, half-maximal inhibitory concentration: 3380 nM
Beside the measured number, compound 4's estimate is 1.1-fold (0.05 log units) below it; measured number inside the range.
By their numbers in this assay, from the lowest: compounds 3, 4, 2 and 1 (each within the scatter of the next).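

In this assay, hydrogen in place of methyl on an oxygen on an aromatic ring gives a 1.1-fold lower number from compound 2 to compound 4 (0.02 log units; within the scatter) and so leaves the number level when 3,4-dimethoxyphenyl becomes 3-hydroxy-4-methoxyphenyl. Set against 3,4,5-trimethoxyphenyl, the same 3-hydroxy-4-methoxyphenyl gives a 1.0-fold higher number from compound 3 to compound 4 (0.02 log units; within the scatter) and is level there too, so these three aryl groups do not separate on the shared core. No evidence at hand accounts for this. On these data alone, whether a carboxylic acid in place of the hydroxy, or a longer chain such as propyl in place of the methyl on that oxygen, would move the number beyond the scatter stays open.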